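Ester variations: buffer stability, working notes on compound 4

This account rests on a few compounds, and the source may have more. Where it says the series, first, only, none or still open, it means among the compounds named here.

Measured compounds:
- compound 1, `CC(C)OC(=O)OCOC(=O)C1=C(S[C@@H]2CN[C@H](C(=O)Nc3cccc(C(=O)O)c3)C2)[C@H](C)[C@@H]2[C@@H]([C@@H](C)O)C(=O)N12`. In a physicochemical assay for metabolic stability, read by LC-MS, in phosphate buffer, with a stated time of 3 h, at pH 7.4, tested at 50 uM (a higher number here means that more of the compound is left, a lower number that less of the compound is left), compound 1 gives > 95%, which is a limit of the assay.
- compound 2, `C[C@@H](O)[C@H]1C(=O)N2C(C(=O)OCC(F)(F)F)=C(S[C@@H]3CN[C@H](C(=O)Nc4cccc(C(=O)O)c4)C3)[C@H](C)[C@H]12`. In this assay compound 2 gives > 95%, again a limit.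
- compound 3, `CC(C)C(=O)OCOC(=O)C1=C(S[C@@H]2CN[C@H](C(=O)Nc3cccc(C(=O)O)c3)C2)[C@H](C)[C@@H]2[C@@H]([C@@H](C)O)C(=O)N12`. In this assay compound 3 gives > 95%, also a limit.

Compound 2 therefore stands at the limit together with the other two, as the limit of > 95% in this assay, at which 3 of the 3 values shown sit, records. The untested compound 4, `C[C@@H](O)[C@H]1C(=O)N2C(C(=O)OCC(F)(F)F)=C(S[C@@H]3CN[C@H](C(=O)Nc4cccc(C(=O)OCC(F)(F)F)c4)C3)[C@H](C)[C@H]12`, differs from compound 2 by 2,2,2-trifluoroethyl in place of hydrogen on an oxygen next to a carbonyl group.

The measured steps all concern the other ester position, and none can be read: a step that the two limits leave unreadable from compound 1 to compound 2; a step that the two limits leave unreadable from compound 2 to compound 3; a step that the two limits leave unreadable from compound 1 to compound 3. Among the measured compounds shown here, no measured step touches the oxygen next to the carbonyl group where compound 4 is changed, so nothing here distinguishes the two esters of compound 4 from the free carboxy of compound 2. With three values all at the limit, no step beyond the scatter is expected in this assay, and the estimated step of a number no higher from compound 2 to compound 4 (the limit leaves the size open) is accordingly flat. Compound 4 is expected to give about 95%, within 85% to 100%, most likely reported as a limit once more.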

Compound 4, percent of the compound remaining: > 95%
Compound 4 was reported as a limit; the forecaster's own chance of this, stated with the estimate: 75%; the middle value sits exactly at the limit.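

Compound 2 and compound 4 both sit at a limit in this assay, so no step can be read between them, nor among compounds 1, 2 and 3: the limit of > 95% in this assay, at which 4 of the 4 values shown sit.

The compounds shown leave open whether any of these ester changes alters the result in this assay at all, with no value off the limit.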